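A few compounds are considered here, and "the series" means these few. Any claim that something is new, unique, unknown or untested is made for them only; others in the source may bear on it.

Notes on the series. Compound 1 `COc1cc(O)c(C(=O)/C=C/c2ccc(OC)c(OCc3cn(-c4ccc(F)c(Cl)c4)nn3)c2)c(OC)c1`, compound 2 `COc1cc(OC)c2c(=O)cc(-c3ccc(OCc4cn(-c5ccc(F)cc5Cl)nn4)c(OC)c3)oc2c1` and compound 3 `COc1cc(OC)c2c(=O)cc(-c3ccc(OCc4cn(-c5ccc(F)c(Cl)c5)nn4)c(OC)c3)oc2c1` have all been run in an ADME assay on Huh-7 cells (Homo sapiens) for cytotoxicity, read by MTT assay, with a stated time of 72 h; a lower number here means that less compound is tolerated, a higher number that more compound is tolerated. In this assay compound 1 gives only a limit, > 100 ug/mL. Compound 2 likewise gives a limit, > 100 ug/mL. Compound 3 gives a limit as well, > 100 ug/mL. The change from compound 3 to compound 2, (2-chloro-4-fluorophenyl in place of 3-chloro-4-fluorophenyl on an aromatic nitrogen), gives a step that the two limits leave unreadable from compound 3 to compound 2, which the two limits leave unreadable. How the core of compound 1 differs from the core of compound 3 is not broken down here. Compound 4 `COc1cc(O)c(C(=O)/C=C/c2ccc(OC)c(OCc3cn(-c4ccc(F)cc4Cl)nn3)c2)c(OC)c1` has not yet been measured; it is made from compound 1 by the same change, (2-chloro-4-fluorophenyl in place of 3-chloro-4-fluorophenyl on an aromatic nitrogen). Among the measured compounds shown here, because of the limit of > 100 ug/mL in this assay, at which 3 of the 3 values shown sit, no step of readable size is expected from compound 1 to compound 4, a step that the limit leaves unreadable from compound 1 to compound 4. The estimated value for compound 4 in this assay is 150 ug/mL, between 70 ug/mL and 400 ug/mL.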

Compound 4, half-maximal cytotoxic concentration: > 100 ug/mL
Compound 4: only a limit was reported; the forecaster's own chance of this, stated with the estimate: 85%; the middle value lies beyond the limit too.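

No step can be read between compound 1 and compound 4, as both give only limits in this assay: the limit of > 100 ug/mL in this assay, at which 4 of the 4 values shown sit.

The compounds shown leave open whether 2-chloro-4-fluorophenyl and 3-chloro-4-fluorophenyl differ at all in this assay.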